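Chalcone anilide series: paw edema inhibition notes

The source may hold more compounds than are shown below. What is called first, only, known or untested is meant among the compounds shown, and "the series" means these compounds.

Measured in a functional assay on the whole organism (strain albino) for inhibition, with Rattus norvegicus as the target, read by paw edema, with stated times of 30 min and 1 h, at a dose of 100 mg/kg by the oral route; a higher number here means more inhibition at the dose given (going by the name of the read-out), a lower number less inhibition:
compound 1 `COc1ccc(/C=C/C(=O)c2ccc(NC(=O)C(C)O[N+](=O)[O-])cc2)cc1` gives 43%
compound 2 `CC(O[N+](=O)[O-])C(=O)Nc1ccc(C(=O)/C=C/c2ccco2)cc1` gives 41%
compound 3 `COc1ccc(/C=C/C(=O)c2ccc(NC(=O)COc3ccc(C(C)=O)cc3)cc2)cc1` gives 28%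

Compound 1 and compound 2 share a core and differ only by furan-2-yl in place of 4-methoxyphenyl on a double-bonded chain carbon bound to a double-bonded chain carbon; the resulting step is a number 2 percentage points lower from compound 1 to compound 2 (within the scatter), so the two numbers cannot be ordered. Compound 3 sits lowest of the three, beyond the scatter from both compound 2 and compound 1; how its core differs from that of compound 1 is not broken down here.

Compound 4 `CC(=O)c1ccc(OCC(=O)Nc2ccc(C(=O)/C=C/c3ccco3)cc2)cc1` is not yet measured. It is derived from compound 3 by furan-2-yl in place of 4-methoxyphenyl on a double-bonded chain carbon bound to a double-bonded chain carbon, the same change that turned compound 1 into compound 2. Because that step read a number 2 percentage points lower from compound 1 to compound 2 (within the scatter), a similar small movement is expected from compound 3 to compound 4, estimated as a number 2 percentage points lower from compound 3 to compound 4 (within the scatter). Compound 4 is therefore expected to give about 26% in this assay, estimated between 14% and 38%.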

Compound 4, a percentage reported as inhibition, in the whole organism at one dose (the size of the read-out at that dose, not a potency): 28%
The estimate for compound 4 lay 2 percentage points below the measured number; the range from low to high includes it.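

In this assay, furan-2-yl in place of 4-methoxyphenyl on a double-bonded chain carbon bound to a double-bonded chain carbon shows no change at the digits printed from compound 3 to compound 4 (within the scatter). Set beside the earlier step, the change reads alike on the two cores: the same change on two cores in this assay, a number 2 percentage points lower (within the scatter) from compound 1 to compound 2 and no change at the digits printed (within the scatter) from compound 3 to compound 4, 2 percentage points apart, within the scatter of two such steps. This shows that on both cores the swap leaves the number within the scatter at the single dose tested; it does not show that the two groups are interchangeable at other doses or on any further core.

The compounds shown leave open whether any group at this place can move the number beyond the scatter, for example an amine or a carboxylic acid in place of the furan-2-yl.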